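Removing a fluoro group from an inactive compound

The source may report more compounds than this note shows. Statements on the series, on what has been measured and on what is new or still open speak of the compounds shown alone.

In a functional assay on A549 cells (Homo sapiens) for antiproliferative activity, read by MTT assay, with a stated time of 72 h (a lower number here means a stronger inhibitor, a higher number a weaker inhibitor), compound 1 (`COc1ccc(/C=N/NC(=O)Nc2ccc(Oc3ccnc4[nH]ccc34)cc2)cc1`) gives 4300 nM, and compound 2 (`O=C(N/N=C/c1ccc(O)cc1Br)Nc1ccc(Oc2ccnc3[nH]ccc23)cc1`) gives 5080 nM. Compound 3 (`CN(C)CCn1cccc1/C=N/NC(=O)Nc1ccc(Oc2ccnc3[nH]ccc23)c(F)c1`) is reported as "not active" (no number reported), without a number, so it has no exact place on the scale set by those two values.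

Compound 4 (`CN(C)CCn1cccc1/C=N/NC(=O)Nc1ccc(Oc2ccnc3[nH]ccc23)cc1`) differs from compound 3 by a single change, hydrogen in place of fluoro on an aromatic carbon. For the measured compounds named here, the only measured step is a 1.2-fold higher number from compound 1 to compound 2 (0.07 log units; within the scatter). That step lies within the scatter, but it concerns the group on a carbon with a double bond to nitrogen rather than the site of the fluoro, so it bears on this change only indirectly. Going by the values given here, no measured pair compares fluoro with hydrogen, and without a number for compound 3 no step size can be derived.

The expectation is therefore cautious: compound 4 may also be reported without a number in this assay. If it does give a number, that number is expected to lie in the same general region as compound 2 at 5080 nM. For compound 4 the estimated value is 7000 nM, with an expected range from 2000 nM to 25000 nM.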

Compound 4, half-maximal inhibitory concentration: "not active" (no number reported)
No number was reported for compound 4, and the estimate cannot be compared.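

In this assay compound 3 and compound 4 are both reported as not active, without a number, so no step can be read for hydrogen in place of fluoro. No other data here bear on this result. The compounds shown leave open whether this exchange changes antiproliferative activity at all.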